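Swapping an Amide-Bearing Ring for a Fluorinated Sulfone Ring

This account rests on a few compounds, and the source may have more. Where it says the series, first, only, none or still open, it means among the compounds named here.

Measured so far:
compound 1 `O=C1NC(=O)C2(CCC(C(=O)N3CC[C@](c4ccc(C(F)(C(F)(F)F)C(F)(F)F)cc4)(S(=O)(=O)c4ccc(F)cc4)C3)CC2)N1`: 84%; 93% (2 entries)
compound 2 `NC(=O)[C@H]1CC[C@H](C(=O)N2CC[C@](c3ccc(C(F)(C(F)(F)F)C(F)(F)F)cc3)(S(=O)(=O)c3ccc(F)cc3)C2)CC1`: 100%

In an ADME assay on microsomes from liver (Homo sapiens) for metabolic stability, with a stated time of 10 min (on this read-out lower numbers stand for a less stable compound and higher numbers for a more stable compound), compound 2 gives 100%, the only number shown for it, while compound 1 gives 84%; 93% (2 entries). Compound 3 `O=C(N1CC[C@](c2ccc(C(F)(C(F)(F)F)C(F)(F)F)cc2)(S(=O)(=O)c2ccc(F)cc2)C1)C1(F)CCS(=O)(=O)CC1` has not yet been measured. It differs from compound 2 in a single place: 4-fluoro-1,1-dioxothian-4-yl in place of 4-carbamoylcyclohexyl on a carbonyl carbon. Going by the values given here, no measured pair shows a change of this kind, so the size of the step is open. The estimated step of a number 10 percentage points lower from compound 2 to compound 3 (within the scatter) is expected to lie within the usual scatter, or at most a small loss. Compound 3 is therefore estimated at 90%, within a range of 72% to 100%.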

Compound 3, percent of the compound remaining: 100%
For compound 3 the middle estimate is 10 percentage points below the measured one; measured number inside the range.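

In this assay the data show no change at the digits printed from compound 2 to compound 3 (within the scatter) when 4-fluoro-1,1-dioxothian-4-yl replaces 4-carbamoylcyclohexyl on a carbonyl carbon. For this pair, then, the reading holds although the ring of carbon only and the hydrogen-bond donor both leave. Repeat entries of a single compound can differ, so one reading per compound deserves some caution: the several entries of compound 1 in this assay, 84%; 93% (2 entries).

On these data alone, what an amine, a carboxylic acid or an open alkyl chain on this carbonyl carbon would give remains open. So does the separate part played by the fluorine and by the ring sulfur with its two oxygens.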